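This account rests on a few compounds, and the source may have more. Where it says the series, first, only, none or still open, it means among the compounds named here.

Measured so far in a functional assay on PC-3 cells (Homo sapiens) for antiproliferative activity, read by MTT assay, with a stated time of 48 h; a higher number here means a weaker inhibitor, a lower number a stronger inhibitor:
Compound 1 `COc1ccc(-c2nn(-c3ccccc3)cc2/C=C/C(=O)c2ccc(OCc3ccccc3)c3c2OC(C)(C)C3)cc1`: compound 1 gives 7900 nM.
Compound 2 `CC1(C)Cc2c(ccc(C(=O)/C=C/c3cn(-c4ccccc4)nc3-c3ccccc3)c2OCc2ccccc2)O1`: compound 2 gives only a limit of the assay, > 100000 nM.
Compound 3 `CC1(C)Cc2c(ccc(C(=O)/C=C/c3ccc(Cl)cc3)c2OCc2ccccc2)O1`: compound 3 likewise gives only a limit, > 100000 nM.

On these data alone, compound 2 therefore stands not at a number but at the limit of > 100000 nM in this assay, at which 2 of the 3 values shown sit, so its true potency is unknown beyond that boundary. Compound 1, which carries a methoxy group on a differently built core, is the only one of the three with a measured number.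

The unmeasured compound 4 `COc1ccc(-c2nn(-c3ccccc3)cc2/C=C/C(=O)c2ccc3c(c2OCc2ccccc2)CC(C)(C)O3)cc1` differs from compound 2 by methoxy in place of hydrogen on an aromatic carbon, on the ring that hangs from the pyrazole. Going by the values given here, no single-change step between measured compounds exists to calibrate this, and compound 1 and compound 2 differ in more than this one place, so their values can only be set side by side. Still, the expectation is that the step from compound 2 to compound 4 in this assay, an at least 3.3-fold lower number from compound 2 to compound 4 (0.52 log units; beyond the scatter), leads toward stronger inhibition and beyond the usual scatter. Compound 4 is estimated at 30000 nM, with a plausible range from 7000 nM to 150000 nM.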

Compound 4, half-maximal inhibitory concentration: 18400 nM
Beside the measured number, compound 4's estimate is 1.6-fold (0.21 log units) above it; the measured number falls inside the stated range.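

In this assay, replacing phenyl with 4-methoxyphenyl gives an at least 5.4-fold lower number from compound 2 to compound 4 (0.73 log units; beyond the scatter). Going by these compounds alone, this is the first direct reading of a single change, and it shows that adding one methoxy group at this position is enough to turn a compound with no measured number into one with a measured number. The true size of the step remains unknown, as compound 2 has only a limit of the assay and not a number: the limit of > 100000 nM in this assay, at which 2 of the 4 values shown sit.

On these data alone, whether this gain is specific to methoxy remains open, as no other group at this position can be compared, such as a hydroxyl, an amine or a longer ethoxy chain. This single pair also cannot show whether the same change would have a similar effect on another core.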